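Chloro to methoxy swap in a small antiproliferative series

The source may report more compounds than this note shows. Statements on the series, on what has been measured and on what is new or still open speak of the compounds shown alone.

Measured so far in a functional assay on HepG2 cells (Homo sapiens) for antiproliferative activity, read by MTT assay, with a stated time of 48 h; a lower number here means a stronger inhibitor, a higher number a weaker inhibitor:
compound 1, `CCn1cc(-c2ccc(Cl)cc2)c(=O)c2cc(F)c(N3CCNCC3)cc21`: 24000 nM
compound 2, `CCn1cc(-c2ccc(OC)cc2)c(=O)c2cc(F)c(N3CCNCC3)cc21`: 57900 nM
compound 3, `O=c1c(-c2cccc(Cl)c2)cn(C2CC2)c2cc(N3CCNCC3)c(F)cc12`: 860 nM

Compound 3 gives the lowest number of the three. The difference between its core and the core of compound 1 is not broken down here. One change occurs twice in the set. In the measured pair it is methoxy in place of chloro on an aromatic carbon and it made a 2.4-fold higher number from compound 1 to compound 2 (0.38 log units; beyond the scatter). The unmeasured compound 4, `COc1cccc(-c2cn(C3CC3)c3cc(N4CCNCC4)c(F)cc3c2=O)c1`, carries the same kind of change, (methoxy in place of chloro on an aromatic carbon), but not the same one: in compound 2 the methoxy stands para to a large group, in compound 4 meta to a large group. For the measured compounds named here, the step to compound 4 is expected to be of similar size, a 2.2-fold higher number from compound 3 to compound 4 (0.34 log units; beyond the scatter), because a 2.4-fold higher number from compound 1 to compound 2 (0.38 log units; beyond the scatter) is the only measured instance of this change. Compound 4 is therefore estimated at 1900 nM in this assay, between 700 nM and 5500 nM.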

Compound 4, half-maximal inhibitory concentration: 910 nM
Compound 4: middle estimate off by 2.1-fold (0.32 log units), on the high side, and the stated range covers the measured number.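

In this assay methoxy in place of chloro on the core of compound 3 gives a 1.1-fold higher number from compound 3 to compound 4 (0.02 log units; within the scatter) and so leaves no difference that can be read on this core. Set beside the earlier step, the two cores do not separate: the same change on two cores in this assay, a 2.4-fold higher number (0.38 log units; beyond the scatter) from compound 1 to compound 2 and a 1.1-fold higher number (0.02 log units; within the scatter) from compound 3 to compound 4, 2.3-fold (0.36 log units) apart, within the scatter of two such steps. This shows that one size of step fits both pairs, but with a single pair per core it does not show that the change carries over reliably, and since the place of the group also differs between the pairs, the effects of core and place cannot be told apart.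

Still open, on these data alone, is how a nitrile, an amine or a carboxylic acid would read in place of the chloro on either core. Also open, as far as these compounds go, is whether a longer chain in place of the methoxy would keep the number of compound 4.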